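The source may hold more compounds than are shown below. What is called first, only, known or untested is meant among the compounds shown, and "the series" means these compounds.

Measured compounds:
- Compound 1, `N#Cc1ccc(Cc2cnc(CCc3ccc(-c4ccccc4C(=O)O)cc3)[nH]2)cc1`: 5890 nM
- Compound 2, `O=C(O)c1ccccc1-c1ccc(CCc2ncc(Cc3cccc(F)c3)[nH]2)cc1`: 159 nM
- Compound 3, `O=C(O)c1ccccc1-c1ccc(CCc2ncc(CC3CC3)[nH]2)cc1`: 1000 nM

These three compounds share a core and differ only in the group on a saturated chain carbon bound to an aromatic carbon. In an in vitro functional assay on cells for agonist activity at Bombesin receptor subtype-3 (Homo sapiens), read by luminescence and calcium flux (a higher number here means that more compound is needed for the effect, a lower number that less compound is needed), compound 3 stands second highest of the three numbers, nearer to compound 1 than to compound 2: the step of a 5.9-fold lower number from compound 1 to compound 3 (0.77 log units; beyond the scatter) and the step of a 6.3-fold higher number from compound 2 to compound 3 (0.80 log units; beyond the scatter) are both beyond the scatter.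

Compound 4, `O=C(O)c1ccccc1-c1ccc(CCc2ncc(Cc3ccccc3)[nH]2)cc1`, is not yet measured. The change is phenyl in place of cyclopropyl on a saturated chain carbon bound to an aromatic carbon. For the measured compounds named here, two measured steps bear on it. The step of a 6.3-fold higher number from compound 2 to compound 3 (0.80 log units; beyond the scatter) shows that a cyclopropyl in this place gives a higher number than a fluorine-bearing phenyl, and the step of a 5.9-fold lower number from compound 1 to compound 3 (0.77 log units; beyond the scatter) shows that a nitrile-bearing phenyl gives a higher number still. The unsubstituted phenyl of compound 4 is closer to the group of compound 2 than to that of compound 1, so a modest step downward in this assay from compound 3 is expected, perhaps not quite matching compound 2. Compound 4 is therefore estimated at 300 nM, with a range from 100 nM to 1000 nM, which means an expected step of a 3.3-fold lower number from compound 3 to compound 4 (0.52 log units; beyond the scatter).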

Compound 4, half-maximal effective concentration: 205 nM
Estimate against measurement, compound 4: 1.5-fold (0.17 log units) above; measured number inside the range.
By their numbers in this assay, from the lowest: compounds 2 and 4 (each within the scatter of the next); then compound 3; then compound 1.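

In this assay, the step of a 4.9-fold lower number from compound 3 to compound 4 (0.69 log units; beyond the scatter) shows that at this place, on a saturated chain carbon bound to an aromatic carbon, benzyl gives a lower number than cyclopropylmethyl, and that an unsubstituted phenyl is enough for this without any added group. Compound 2 had left open whether the fluoro group contributed to its low number, but the step of a 1.3-fold higher number from compound 2 to compound 4 (0.11 log units; within the scatter) lies within the scatter, so hydrogen and fluoro on the aromatic carbon cannot be told apart here. For the compounds shown here, the high number of compound 1 can now be tied to the cyano group rather than to the phenyl ring itself, since the step of a 29-fold lower number from compound 1 to compound 4 (1.46 log units; beyond the scatter) is large and changes only that group.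

The compounds shown leave open how a hydroxyl group or an amine on the phenyl would compare with fluoro and cyano, whether a cyclohexyl group would fall nearer to the cyclopropyl or the phenyl, and how a longer chain carrying the phenyl would compare with benzyl. The data shown also offer no measurement that accounts for any of these differences.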